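The source may report more compounds than this note shows. Statements on the series, on what has been measured and on what is new or still open speak of the compounds shown alone.

Going by the values given here, only two compounds have a number so far in a physicochemical assay for acid dissociation. Compound 1 `CN(Cc1ccc(Cl)cc1)Cc1ccc(CNc2ccnc3cc(Cl)ccc23)cc1` gives 7.44, and compound 2 `CN(Cc1ccc(Cl)cc1)Cc1cccc(CNc2ccnc3cc(Cl)ccc23)c1` gives 7.55. These two numbers lie within the usual scatter of each other, so compound 1 stands level with compound 2.

Compound 3 `COc1ccc(CN(C)Cc2ccc(CNc3ccnc4cc(Cl)ccc34)cc2)cc1` is still waiting for its measurement. It differs from compound 1 in one place, with methoxy in place of chloro on an aromatic carbon, so that 4-chlorobenzyl becomes 4-methoxybenzyl (methoxy in place of chloro on an aromatic carbon). The exchange sits on a six-membered aromatic ring of carbon only, para to a large group, and the rest of the structure is unchanged.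

Among the compounds with values here, no measured pair shows what this exchange does in this assay, so the expectation is tentative and starts from compound 1 at 7.44. The expected step of a number 0.16 log units higher from compound 1 to compound 3 (within the scatter) is small and slightly upward, and it is not expected to go clearly beyond the scatter. For compound 3 the estimated value is 7.6, with an expected range from 7.2 to 8.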

Compound 3, acid dissociation constant: 7.44
Beside the measured number, compound 3's estimate is 0.16 log units above it; low and high end bracket the measured number.
By their numbers in this assay, from the lowest: compounds 1, 3 and 2 (each within the scatter of the next).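

In this assay, going by these compounds alone, methoxy in place of chloro on an aromatic carbon gives no change at the digits printed from compound 1 to compound 3 (within the scatter), and this pair is the first reading of any exchange at this place. It shows that, on a six-membered aromatic ring of carbon only, para to a large group, 4-chlorobenzyl and 4-methoxybenzyl stand level in this read-out, although methoxy counts as a hydrogen-bond acceptor and chloro does not, and the two groups differ in their heavy atoms. Nothing available on these compounds offers an explanation for this outcome.

What the compounds shown leave open is how far this level reading extends, since a single pair cannot show whether the position is generally indifferent in this read-out or whether these two groups simply happen to match. An amine, a carboxylic acid or a longer alkoxy chain at the same place could answer that, as could the same exchange of chloro for methoxy made on compound 2.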